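Glucosamide series: permeability across a single aromatic methyl change

The compounds below may be only part of what the source reports. "The series", "measured", "known", "first", "only" and "open" are said of these compounds alone.

Measured compounds:
compound 1 `COc1cc(/C=C/C(=O)N[C@@H]2O[C@H](CO)[C@@H](O)[C@H](O)[C@H]2O)cc(OC)c1` 80 nm/s
compound 2 `Cc1ccc(-c2cnc(CCC(=O)N[C@@H]3O[C@H](CO)[C@@H](O)[C@H](O)[C@H]3O)o2)cc1` 54 nm/s

In an ADME assay on Caco-2 cells (Homo sapiens) for permeability (a higher number here means that the compound crosses the layer faster, a lower number that the compound crosses the layer more slowly), compound 2 gives 54 nm/s, the lower of the two numbers recorded; compound 1 gives 80 nm/s, and the two values lie within the scatter of each other. Compound 3 `O=C(CCc1ncc(-c2ccccc2)o1)N[C@@H]1O[C@H](CO)[C@@H](O)[C@H](O)[C@H]1O` is not yet measured. Its difference from compound 2 is hydrogen in place of methyl on an aromatic carbon. Among the measured compounds shown here, no step between measured compounds is available for this change, so the size of the step in this assay is expected to be small, likely within the scatter, with no clear direction. The step from compound 2 to compound 3 is estimated at a 1.1-fold lower number from compound 2 to compound 3 (0.05 log units; within the scatter). Compound 3 is expected at 48 nm/s, within 22 nm/s to 100 nm/s.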

Compound 3, apparent permeability in the Caco-2 assay: 36.5 nm/s
Beside the measured number, compound 3's estimate is 1.3-fold (0.12 log units) above it; low and high end bracket the measured number.
By their numbers in the Caco-2 assay, from the lowest: compounds 3, 2 and 1 (each within the scatter of the next, the first and the last beyond it).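

The first step read at this position in the Caco-2 assay is a 1.5-fold lower number from compound 2 to compound 3 (0.17 log units; within the scatter), for the change from 4-methylphenyl to phenyl. In a physicochemical assay for lipophilicity, measured as octanol-water partition (on this read-out lower numbers stand for lower lipophilicity and higher numbers for higher lipophilicity), compound 2 gives -0.574 and compound 3 gives -0.915. In the physicochemical assay the same change gives a difference beyond the scatter, so at this position the partition coefficient separates the pair while permeability does not: the measured partition coefficient of compound 2, -0.574, and of compound 3, -0.915, a number 0.34 log units lower (beyond the scatter)

As far as these compounds go, whether an amine, a methoxy group or a chlorine at this position would give a permeability step beyond the scatter stays open. From the compounds shown here alone, how far permeability follows the partition coefficient also stays open, since a single pair carries both read-outs.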